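The source may hold more compounds than are shown below. What is called first, only, known or untested is meant among the compounds shown, and "the series" means these compounds.

In an ADME assay on L6 cells (Rattus norvegicus) for cytotoxicity, read by fluorescence and resazurin assay, with a stated time of 72 h (a higher number here means that more compound is tolerated, a lower number that less compound is tolerated), compound 1 `CC(C)(C)c1ccc(-c2c[nH]cc2C(c2ccc(Cl)cc2Cl)n2ccnc2)cc1` gives 22900 nM, compound 2 `Clc1ccc(-c2c[nH]cc2C(c2ccc(Cl)cc2Cl)n2ccnc2)cc1` gives 9610 nM and compound 3 `O=[N+]([O-])c1ccc(-c2c[nH]cc2C(c2ccc(Cl)cc2Cl)n2ccnc2)cc1` gives 16900 nM, a value within the scatter of both others. Compound 4 `CSc1ccc(-c2c[nH]cc2C(c2ccc(Cl)cc2Cl)n2ccnc2)cc1` follows from compound 3 through (methylsulfanyl in place of nitro on an aromatic carbon), methylsulfanyl in place of nitro on an aromatic carbon. Among the compounds with values here, no measured compound carries methylsulfanyl, but three swaps on that carbon bear on the change: a 1.8-fold higher number from compound 2 to compound 3 (0.25 log units; within the scatter), a 1.4-fold lower number from compound 1 to compound 3 (0.13 log units; within the scatter) and a 2.4-fold lower number from compound 1 to compound 2 (0.38 log units; beyond the scatter). Only the last lies beyond the scatter, and it is modest. A step of similar small size is therefore expected, with no clear direction and probably none beyond the scatter. The estimated result is a 1.1-fold lower number from compound 3 to compound 4 (0.05 log units; within the scatter). Compound 4 is expected at 15000 nM, within an estimated range of 7500 nM to 30000 nM.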

Compound 4, half-maximal cytotoxic concentration: 7220 nM
The estimate for compound 4 lay 2.1-fold (0.32 log units) above the measured number, outside the stated range (below it).
By their numbers in this assay, from the lowest: compounds 4, 2, 3 and 1 (each within the scatter of the next, the first and the last beyond it).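

Methylsulfanyl shows that replacing nitro at this position can give a step beyond the scatter in this assay: a 2.3-fold lower number from compound 3 to compound 4 (0.37 log units; beyond the scatter), whereas the earlier steps involving nitro stayed within it. Against chloro the change stays within the scatter, a 1.3-fold lower number from compound 2 to compound 4 (0.12 log units; within the scatter), while against tert-butyl it gives the widest step so far, a 3.2-fold lower number from compound 1 to compound 4 (0.50 log units; beyond the scatter), though this is still modest. Nothing available explains these differences. As far as these compounds go, whether an amine, a carboxylic acid or a methoxy group on this carbon would fall within the same span remains open.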